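Chloro in place of benzoyl on an aromatic carbon

The source may hold more compounds than are shown below. What is called first, only, known or untested is meant among the compounds shown, and "the series" means these compounds.

In a functional assay on HCT-116 cells (Homo sapiens) for inhibition, read by colorimetric assay, with a stated time of 3 days (a higher number here means a weaker inhibitor, a lower number a stronger inhibitor), compound 1 `O=C(CCCCCCNC(=O)C(O)(O)C(F)(F)F)Nc1ccccc1Br` gives 14500 nM and compound 2 `COc1ccc(NC(=O)CCCCCCNC(=O)C(O)(O)C(F)(F)F)cc1` gives 4520 nM. The change between them, 4-methoxyphenyl in place of 2-bromophenyl on an amide-type nitrogen, is a 3.2-fold lower number from compound 1 to compound 2 (0.51 log units; beyond the scatter).

Compound 3 `O=C(CCCCCCNC(=O)C(O)(O)C(F)(F)F)Nc1ccc(C(=O)c2ccccc2)cc1` stands at a limit of the assay, > 40000 nM, and not at a number. With benzoyl in place of methoxy on an aromatic carbon, the record shows an at least 8.8-fold higher number from compound 2 to compound 3 (0.94 log units; beyond the scatter).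

Compound 4 `O=C(CCCCCCNC(=O)C(O)(O)C(F)(F)F)Nc1ccc(Cl)cc1` has not yet been measured in this assay. It differs from compound 3 by chloro in place of benzoyl on an aromatic carbon, which puts chloro in place of benzoyl on an aromatic carbon, para to a large group.

The step that bears most directly is the one from methoxy to benzoyl, an at least 8.8-fold higher number from compound 2 to compound 3 (0.94 log units; beyond the scatter), since it changes the same carbon and also ends in benzoyl. The step of a 3.2-fold lower number from compound 1 to compound 2 (0.51 log units; beyond the scatter) concerns a different change and serves only to widen the range. A move to a lower number, of at least modest size, is therefore expected.

The expected step is an at least 5.7-fold lower number from compound 3 to compound 4 (0.75 log units; beyond the scatter).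

The estimated value for compound 4 is 7000 nM.

The expected range for compound 4 runs from 2500 nM to 20000 nM.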

Compound 4, half-maximal inhibitory concentration: 4230 nM
Compound 4: middle estimate off by 1.7-fold (0.22 log units), on the high side; the measured number falls inside the stated range.
By their numbers in this assay, from the lowest: compounds 4 and 2 (each within the scatter of the next); then compound 1. At a limit, above all of these: compound 3.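

In this assay, the carbon that carries benzoyl in compound 3 tolerates two quite different replacements: chloro gives an at least 9.4-fold lower number from compound 3 to compound 4 (0.97 log units; beyond the scatter), while exchanging methoxy for chloro gives a 1.1-fold lower number from compound 2 to compound 4 (0.03 log units; within the scatter), so compound 2 and compound 4 cannot be told apart and the weak result is confined to the benzoyl compound among these three. The 4-chlorophenyl group also gives a 3.4-fold lower number from compound 1 to compound 4 (0.54 log units; beyond the scatter), which makes two compounds with a single group on this carbon that read lower than the 2-bromophenyl compound, although compound 3 goes against any such pattern. Compound 3 stands at a limit of the assay and not at a number, so the true size of its step remains unknown: the limit of > 40000 nM in this assay, at which 1 of the 4 values shown sits.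

Still open, as far as these compounds go, is whether an acetyl or phenyl group on this same carbon would read with compound 2 and compound 4 or with compound 3, and what an amine or a carboxylic acid there would give. From the compounds shown here alone, it is also open whether the gap to compound 1 follows from the bromo group itself or from its place on the ring, which a bromo group on the carbon carrying chloro in compound 4 would help to separate.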